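A Methoxypyridine Swap Tested for Oral Exposure in Rats

The source may report more compounds than this note shows. Statements on the series, on what has been measured and on what is new or still open speak of the compounds shown alone.

Three compounds share one core. In an ADME assay on the whole organism for pharmacokinetics, with Rattus norvegicus as the target, with a stated time of 6 h, at a dose of 10 mg/kg by the oral route (a lower number here means less compound in the circulation, a higher number more compound in the circulation at the dose given), compound 1 `Cc1cn2c(-c3cn[nH]c3)cnc2c(Nc2cc(Cn3cccc3)ns2)n1` gives "not determined" (no result reported), so no number is available for it. Among the compounds with values here, compound 2 `Cc1cn2c(-c3cn[nH]c3)cnc2c(Nc2cc(Cc3ncccc3C)ns2)n1` gives 644 ng.h/mL in this assay, the only number available, so it stands alone as the point of reference rather than at the top or bottom of any ranking. Compound 3 `COc1cccc(Cc2cc(Nc3nc(C)cn4c(-c5cn[nH]c5)cnc34)sn2)n1` has not yet been measured. It differs from compound 2 in a single place: 6-methoxypyridin-2-yl in place of 3-methylpyridin-2-yl on a saturated chain carbon bound to an aromatic carbon. Within the data shown here, no measured step between any two compounds is available, so the size of this change cannot be read from earlier data. The expected step in this assay is a 1.4-fold lower number from compound 2 to compound 3 (0.16 log units; within the scatter), a modest fall that may well sit within the usual scatter of repeated measurements. Compound 3 is expected to reach about 450 ng.h/mL in this assay, with a plausible range from 130 ng.h/mL to 1600 ng.h/mL.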

Compound 3, area under the concentration-time curve: 2300 ng.h/mL
Compound 3: the middle estimate sits 5.1-fold (0.71 log units) below what was measured; the whole stated range lies below it.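

In this assay, replacing 3-methylpyridin-2-yl with 6-methoxypyridin-2-yl on a saturated chain carbon bound to an aromatic carbon gives a 3.6-fold higher number from compound 2 to compound 3 (0.55 log units; beyond the scatter). This first readable step shows that the group at this position can alter how much compound reaches the circulation after an oral dose, and that this change raises the number. No measurement available here accounts for the rise.

Within the data shown here, with no number for compound 1, no step involving it can be read, so the pyrrole-bearing compound cannot be placed against the two pyridines. From the compounds shown here alone, it also remains open whether a plain pyridin-2-yl, or a pyridine carrying an amine or a longer ether chain such as ethoxy, would give a similar number.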